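The compounds below may be only part of what the source reports. "The series", "measured", "known", "first", "only" and "open" are said of these compounds alone.

Measured so far in an assay on CHO cells for displacement of a labelled ligand from adenosine receptor A1 (Homo sapiens); on this read-out higher numbers stand for weaker inhibition and lower numbers for stronger inhibition:
compound 1 `CCOC(=O)c1cnc(NCc2ccc(F)cc2)n2nc(-c3ccco3)nc12`: 932 nM
compound 2 `CNc1ncc(C(=O)O)c2nc(-c3ccco3)nn12`: > 100000 nM, which is a limit of the assay and not a number
compound 3 `CCNc1ncc(C(=O)O)c2nc(-c3ccco3)nn12`: 11900 nM

Compound 3 carries the highest of the two numbers shown in this assay; compound 1 sits well lower, and compound 2 gives only a limit (the limit of > 100000 nM in this assay, at which 1 of the 3 values shown sits). Among the compounds with values here, the single change between compound 2 and compound 3 is an at least 8.4-fold lower number from compound 2 to compound 3 (0.92 log units; beyond the scatter), so lengthening the chain on this nitrogen has so far moved the number down.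

Compound 4 `Cc1ccc(CNc2ncc(C(=O)O)c3nc(-c4ccco4)nn23)cc1` differs from compound 3 by 4-methylphenyl in place of methyl on a saturated chain carbon bound to a nitrogen on an aromatic ring. Within the data shown here, the step from compound 2 to compound 3 is the only one-place change measured and it points downward; compound 1, which also carries a benzyl group on this nitrogen, gives 932 nM, but it differs from compound 3 in more than one place, so it is a loose guide only. A further drop in this assay is expected, beyond the scatter, roughly toward the level of compound 1. Compound 4 is therefore expected at 1500 nM, between 400 nM and 6000 nM. The expected step is a 7.9-fold lower number from compound 3 to compound 4 (0.90 log units; beyond the scatter).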

Compound 4, inhibition constant: 2730 nM
Compound 4: middle estimate off by 1.8-fold (0.26 log units), on the low side; measured number inside the range.
By their numbers in this assay, from the lowest: compound 1; then compound 4; then compound 3. At a limit, above all of these: compound 2.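

In this assay, 4-methylphenyl in place of methyl on a saturated chain carbon bound to a nitrogen on an aromatic ring gives a 4.4-fold lower number from compound 3 to compound 4 (0.64 log units; beyond the scatter), so the downward run on this nitrogen does not stop at ethyl and carries on with a six-membered aromatic ring in the chain. Counted over both changes, the shift reads an at least 36-fold lower number from compound 2 to compound 4 (1.56 log units; beyond the scatter). Compound 2 gives a limit and not a number, so this longer step is a bound only: the limit of > 100000 nM in this assay, at which 1 of the 4 values shown sits.

Going by these compounds, whether a plain benzyl or a propyl chain on this nitrogen would read differently from 4-methylbenzyl and ethyl stays open. On these data alone, compound 1 differs from compound 4 in more than one place, so the separate weight of the carboxylic acid, against an ester or an amide, also stays open.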